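A few compounds are considered here, and "the series" means these few. Any claim that something is new, unique, unknown or untested is made for them only; others in the source may bear on it.

Measured compounds:
- compound 1, `CN(C)CCCOc1ccc(CN(C)CCCNC(=O)c2ccc(Cl)c(Cl)c2)cc1`: > 10000 nM
- compound 2, `Cc1cc(CN2CC[C@H](NC(=O)c3ccc(Cl)c(Cl)c3)C2)ccc1OC1CCN(C)C1`: 108 nM
- compound 3, `O=C(N[C@H]1CCN(S(=O)(=O)c2ccc(OC3CCNCC3)c(Br)c2)C1)c1ccc(Cl)c(Cl)c1`: 120 nM

In an assay on HEK293 cells for displacement of a labelled ligand from Urotensin-2 receptor (Homo sapiens) (on this read-out higher numbers stand for weaker inhibition and lower numbers for stronger inhibition), compound 1 returns only a limit, > 10000 nM; it is a limit of the assay and not a number. In this assay compound 2 gives 108 nM and compound 3 gives 120 nM. Of the two numbers shown, compound 3 carries the higher one, but compound 2 sits so close that the two values lie within the scatter of each other, so no order between them is claimed.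

The next compound is compound 4, `O=C(N[C@@H]1CCN(S(=O)(=O)c2ccc(OC3CCNCC3)c(Br)c2)C1)c1ccc(Cl)c(Cl)c1`, not yet measured in this assay. It differs from compound 3 as follows: the two compounds have the same atoms and bonds and differ only in configuration as drawn: 1 of 1 stereo elements differ; a stereocentre at a saturated ring carbon is drawn S in compound 3 and R in compound 4. The change is thus a single inversion of configuration at the saturated ring carbon that carries the amide nitrogen.

No measured step of this kind exists among the compounds shown, so the size of the effect of the inversion is open. On these data alone, both numbers that exist, compound 2 at 108 nM and compound 3 at 120 nM, belong to compounds drawn S at that carbon; the R configuration is untested. The expected step from compound 3 to compound 4 is an increase, a 13-fold higher number from compound 3 to compound 4 (1.10 log units; beyond the scatter), with wide uncertainty. Compound 4 is estimated at 1500 nM, with a range from 200 nM to 10000 nM.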

Compound 4, inhibition constant: 380 nM
Compound 4: the middle estimate sits 3.9-fold (0.60 log units) above what was measured, within the range that was stated.
By their numbers in this assay, from the lowest: compounds 2 and 3 (each within the scatter of the next); then compound 4. At a limit, above all of these: compound 1.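

In this assay, among these compounds, the single inversion at the saturated ring carbon that carries the amide nitrogen gives a 3.2-fold higher number from compound 3 to compound 4 (0.50 log units; beyond the scatter), the first measured evidence that this stereocentre affects the read-out. The step is modest, and compound 4, drawn R, still gives a numerical value of 380 nM, so within this pair the R configuration lowers but does not abolish inhibition. The step can be assigned to the configuration at this one carbon alone, because of the following: the fact that compounds 3 and 4 differ only in the configuration as drawn

Compound 2 has no partner of opposite configuration among the compounds shown, so whether a step of this size holds outside the sulfonyl-linked pair cannot be read. Also open, on these data alone, is whether the same preference for S would persist with a methoxy group in place of the bromine, or with a carboxylic acid in place of the secondary amine.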